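This account rests on a few compounds, and the source may have more. Where it says the series, first, only, none or still open, it means among the compounds named here.

Compound 1 `CCCCNc1nc(N)nc2c1CN(C(C)=O)CC2`: 0.5 uM
Compound 2 `CCCCNc1nc(N)nc2c1CN(C(=O)CC)CC2`: 0.4 uM

In an assay on HEK293 cells for agonist activity at Toll-like receptor 8 (Homo sapiens), read by a luciferase reporter, with a stated time of 6 h (on this read-out lower numbers stand for an effect already at smaller amounts and higher numbers for an effect only at larger amounts of compound), compound 2 gives 0.4 uM, the lowest of the two numbers, with compound 1 the nearest; the step of a 1.3-fold lower number from compound 1 to compound 2 (0.10 log units; within the scatter) is within the scatter. Compound 3 `CCCCNc1nc(N)nc2c1CN(C(=O)c1cscn1)CC2` follows from compound 2 by one change, (1,3-thiazol-4-yl in place of ethyl on a carbonyl carbon). For the measured compounds named here, only the step from compound 1 to compound 2 bears on this change, and it was small, so the expectation for compound 3 in this assay is a step of a 1.3-fold higher number from compound 2 to compound 3 (0.10 log units; within the scatter) of no clear direction beyond the scatter. Compound 3 is therefore estimated at 0.5 uM, within 0.1 uM to 2.5 uM.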

Compound 3, minimum effective concentration: 0.5 uM
Compound 3: the middle estimate sits on the measured number at the digits printed; the range from low to high includes it.
By their numbers in this assay, from the lowest: compounds 2, 1 and 3 (each within the scatter of the next).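

In this assay, a five-membered aromatic ring with 2 hetero atoms can stand on this carbonyl carbon, whose other neighbour is an amide-type nitrogen in a ring, without a change beyond the scatter. Until now only small saturated chains had been compared there. Replacing ethyl with 1,3-thiazol-4-yl gives a 1.3-fold higher number from compound 2 to compound 3 (0.10 log units; within the scatter), and replacing methyl with the same ring gives no change at the digits printed from compound 1 to compound 3 (within the scatter). No available evidence explains this result. The compounds shown leave open whether phenyl, a longer chain, an amine or a carboxylic acid on this carbonyl carbon would also stay within the scatter.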